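From dimethylphenyl to dichlorophenyl on the sulfonamide nitrogen

The source may report more compounds than this note shows. Statements on the series, on what has been measured and on what is new or still open speak of the compounds shown alone.

Compound 1 `O=S(=O)(Nc1ccc(Cl)c(F)c1)c1ccc(-c2cnc(C3CC3)o2)cc1`: 63000 nM
Compound 2 `Cc1ccc(NS(=O)(=O)c2ccc(-c3cnc(C4CC4)o3)cc2)cc1C`: > 100000 nM (a limit)

In a functional assay on cells (leukaemia cell line, Homo sapiens) for inhibition, read by sulforhodamine B assay, with a stated time of 48 h (on this read-out lower numbers stand for stronger inhibition of growth and higher numbers for weaker inhibition of growth), compound 2 gives > 100000 nM, which is a limit of the assay and not a number. Compound 2 thus stands at the limit of > 100000 nM in this assay, at which 1 of the 2 values shown sits. Compound 3 `O=S(=O)(Nc1cc(Cl)ccc1Cl)c1ccc(-c2cnc(C3CC3)o2)cc1` carries 2,5-dichlorophenyl in place of 3,4-dimethylphenyl on a sulfonamide nitrogen, and the shared core is unchanged: 2,5-dichlorophenyl in place of 3,4-dimethylphenyl on a sulfonamide nitrogen. Within the data shown here, one measured step bears on this change, an at least 1.5-fold higher number from compound 1 to compound 2 (0.20 log units; that floor lies within the scatter). It sets only a floor, so it gives no firm size. Compound 1 has a chlorine-bearing group at the same place and gives 63000 nM, and compound 3 also carries chlorine there. On that single comparison, a modest move towards a lower number is expected in this assay, though compound 3 may also reach the limit. The estimated step is an at least 1.6-fold lower number from compound 2 to compound 3 (0.22 log units; that floor lies within the scatter). Compound 3 is expected at 60000 nM, with an estimated range of 25000 nM to 100000 nM.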

Compound 3, concentration for total growth inhibition: > 100000 nM
Compound 3: only a limit was reported (the forecaster's own chance of this, stated with the estimate: 35%); middle value at least 1.6-fold (0.22 log units) from the limit.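

In this assay compound 3 gives > 100000 nM, which is a limit of the assay and not a number. Chlorine on the phenyl group on the sulfonamide nitrogen therefore does not by itself give a readable value in this series; the change to 2,5-dichlorophenyl gives an at least 1.5-fold higher number from compound 1 to compound 3 (0.20 log units; that floor lies within the scatter), and that floor does not separate it from 4-chloro-3-fluorophenyl. The step between compound 2 and compound 3 cannot be read, and most of what is shown at this position sits at one limit: the limit of > 100000 nM in this assay, at which 2 of the 3 values shown sit.

Going by these compounds, how far compound 2 and compound 3 lie past that limit stays open, so the two groups cannot be ranked. Also open, on these data alone, is whether an aminophenyl or a carboxyphenyl group, or a longer chain, on the sulfonamide nitrogen would give a readable value.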